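Reworking the Amine Substituent in a Cytotoxicity Series

A few compounds are considered here, and "the series" means these few. Any claim that something is new, unique, unknown or untested is made for them only; others in the source may bear on it.

Of the compounds shown here, three built on one shared core have been measured in a functional assay on MT4 cells (Homo sapiens); a higher number here means that more compound is tolerated, a lower number that less compound is tolerated. Compound 1 `Cc1cn([C@@H]2O[C@H](CO[Si](C)(C)C(C)(C)C)[C@@]3(OS(=O)(=O)C=C3NCCC(N)=O)[C@H]2O[Si](C)(C)C(C)(C)C)c(=O)n(C)c1=O` gives 20000 nM. Compound 2 `Cc1cn([C@@H]2O[C@H](CO[Si](C)(C)C(C)(C)C)[C@@]3(OS(=O)(=O)C=C3NCCC(=O)O)[C@H]2O[Si](C)(C)C(C)(C)C)c(=O)n(C)c1=O`, with hydroxy in place of amino on a carbonyl carbon, gives 11500 nM, a step of a 1.7-fold lower number from compound 1 to compound 2 (0.24 log units; within the scatter). Compound 3 `Cc1cn([C@@H]2O[C@H](CO[Si](C)(C)C(C)(C)C)[C@@]3(OS(=O)(=O)C=C3NCC(=O)C(N)=O)[C@H]2O[Si](C)(C)C(C)(C)C)c(=O)n(C)c1=O` gives 9590 nM, the lowest of the three numbers; it sits within the scatter of compound 2, a 1.2-fold lower number from compound 2 to compound 3 (0.08 log units; within the scatter), while the step of a 2.1-fold lower number from compound 1 to compound 3 (0.32 log units; beyond the scatter) is modest.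

Compound 4 `C=C(C)C(=O)NC(=O)NC1=CS(=O)(=O)O[C@@]12[C@@H](CO[Si](C)(C)C(C)(C)C)O[C@@H](n1cc(C)c(=O)n(C)c1=O)[C@@H]2O[Si](C)(C)C(C)(C)C` awaits measurement. It differs from compound 3 only in the group on the amine nitrogen: ((1-methylethenyl)carbonyl)carbamoyl in place of (carbamoylcarbonyl)methyl on an amine nitrogen. The two earlier changes at this same nitrogen bear on the new one, and both gave small steps, one within the scatter and one just beyond it. For the measured compounds named here, a larger group enters here, yet nothing among the measured compounds points to a particular direction, so the expected step is none beyond the scatter. For compound 4 the expected value in this assay is 9000 nM, with a range from 4000 nM to 22000 nM. This estimate means an expected step of a 1.1-fold lower number from compound 3 to compound 4 (0.03 log units; within the scatter).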

Compound 4, half-maximal cytotoxic concentration: 1190 nM
Estimate against measurement, compound 4: 7.6-fold (0.88 log units) above; the whole stated range lies above it.
By their numbers in this assay, from the lowest: compound 4; then compounds 3, 2 and 1 (each within the scatter of the next, the first and the last beyond it).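

In this assay, for the compounds shown here, the steps of an 8.1-fold lower number from compound 3 to compound 4 (0.91 log units; beyond the scatter) and a 9.7-fold lower number from compound 2 to compound 4 (0.99 log units; beyond the scatter) and a 17-fold lower number from compound 1 to compound 4 (1.23 log units; beyond the scatter) all lie beyond the scatter and show that the substituent on the amine nitrogen can shift this number well past the small changes seen among the earlier compounds. With ((1-methylethenyl)carbonyl)carbamoyl on that nitrogen, less compound is tolerated than with any of the three earlier substituents, so the position is far less indifferent than those compounds alone suggested. No available evidence accounts for the size of this change.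

The compounds shown leave open whether the 1-methylethenyl end or the carbamoyl attached to the amine nitrogen carries the shift. An isopropyl group in place of the 1-methylethenyl, or a plain acetyl on that nitrogen, would begin to separate the two.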